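From a Saturated Ring to an Aromatic Ring on a Carbonyl Carbon

This account rests on a few compounds, and the source may have more. Where it says the series, first, only, none or still open, it means among the compounds named here.

Measured compounds:
compound 1: `O=C(Nc1ccc(OC(F)(F)F)cc1)NC1CCN(C(=O)C2CCCOC2)CC1` — 3.42
compound 2: `CCOC(=O)N1CCC(NC(=O)Nc2ccc(C(F)(F)F)c(F)c2)CC1` — 5.46
compound 3: `O=C(Nc1ccc(C(F)(F)F)c(F)c1)NC1CCN(C(=O)C2(C(F)(F)F)CC2)CC1` — 5.52
compound 4: `Cc1ccoc1C(=O)N1CCC(NC(=O)Nc2ccc(OC(F)(F)F)cc2)CC1` — not yet measured

In a physicochemical assay for lipophilicity, read by HPLC, with a stated time of 90 min, tested at 100 uM (on this read-out higher numbers stand for higher lipophilicity and lower numbers for lower lipophilicity), compound 1 gives 3.42, the lowest of the three numbers. The nearest to it is compound 2, whose value of 5.46 lies beyond the scatter above it, and furthest is compound 3, which gives 5.52, also beyond the scatter. Compound 4 is built from compound 1 by one change: 3-methylfuran-2-yl in place of oxan-3-yl on a carbonyl carbon.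

Among the measured compounds shown here, only one measured step is available, and it bears on this change just loosely. It also sits on a carbonyl carbon joined to an amide-type nitrogen in a ring, but it swaps different groups, and it came out as a number 0.06 log units higher from compound 2 to compound 3 (within the scatter). For the measured compounds named here, no measured pair trades a six-membered non-aromatic ring for a five-membered aromatic one, so the size of the coming step rests on the structural change alone. A rise beyond the scatter is expected, of about a number 0.78 log units higher from compound 1 to compound 4 (beyond the scatter). Compound 4 is therefore estimated at 4.2, with a range from 3.6 to 4.8.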

Compound 4, partition coefficient: 4.48
Compound 4: the middle estimate sits 0.28 log units below what was measured, and the stated range covers the measured number.
By their numbers in this assay, from the lowest: compound 1; then compound 4; then compounds 2 and 3 (each within the scatter of the next).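

In this assay, among the compounds shown here, this position proves responsive: the exchange of oxan-3-yl for 3-methylfuran-2-yl on a carbonyl carbon gives a number 1.06 log units higher from compound 1 to compound 4 (beyond the scatter), whereas the only earlier step at a carbonyl carbon, a number 0.06 log units higher from compound 2 to compound 3 (within the scatter), stayed within the scatter. The new step is also the cleaner of the two, since the groups that leave and enter match in their counts of heavy atoms, carbon, oxygen, hydrogen-bond donors and hydrogen-bond acceptors, and both carry no net charge, so a large shift appears here without any of those counts moving. What does differ is the ring itself, a six-membered non-aromatic ring giving way to a five-membered aromatic one carrying a methyl group, and nothing at hand accounts for how this produces the shift.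

The compounds shown leave open how much of the step belongs to the methyl group and how much to the furan ring, a question that an unsubstituted furan-2-yl on the same carbonyl carbon would address. They also leave open how far the number would move with a phenyl ring, or with an amine or a carboxylic acid carried on the group at this position.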